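Adding a Methyl to Compound 2

The source may report more compounds than this note shows. Statements on the series, on what has been measured and on what is new or still open speak of the compounds shown alone.

Measured so far:
- Compound 1 `COc1cc2c(Oc3ccc(NC(=O)c4nn(-c5ccccc5C)cc(C)c4=O)cc3)ccnc2cc1OCC(=O)NO`: 5980 nM
- Compound 2 `COc1cc2c(Oc3ccc(NC(=O)c4nn(-c5ccccc5C)ccc4=O)cc3)ccnc2cc1OCCCCCC(=O)NO`: 3920 nM

Going by the values given here, both compounds have been tested in a functional assay on A549 cells (Homo sapiens) for inhibition, read by MTT assay, with a stated time of 72 h; a lower number here means a stronger inhibitor, a higher number a weaker inhibitor. There, compound 2 gives 3920 nM and compound 1 gives 5980 nM. These two numbers lie within the usual scatter of each other, so neither compound can be called the stronger one.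

The next compound to consider is compound 3 `COc1cc2c(Oc3ccc(NC(=O)c4nn(-c5ccccc5C)cc(C)c4=O)cc3)ccnc2cc1OCCCCCC(=O)NO`. It is built from compound 2 by one small change: methyl in place of hydrogen on an aromatic carbon. In words, a methyl sits in place of a hydrogen on an aromatic carbon, opposite the ring nitrogen.

Among the compounds with values here, no two measured compounds differ in one place only, so the data offer no direct measure of what this change does. With so little to go on, the expectation in this assay is no step beyond the scatter, in either direction. Within the data shown here, the only support is that compound 1 at 5980 nM and compound 2 at 3920 nM sit close together.

The expected change is a 1.0-fold higher number from compound 2 to compound 3 (0.01 log units; within the scatter).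

For compound 3 the estimated value is 4000 nM, with an expected range of 1800 nM to 9000 nM.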

Compound 3, half-maximal inhibitory concentration: 1820 nM
Beside the measured number, compound 3's estimate is 2.2-fold (0.34 log units) above it; low and high end bracket the measured number.
By their numbers in this assay, from the lowest: compound 3; then compounds 2 and 1 (each within the scatter of the next).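

In this assay, placing a methyl on the aromatic carbon opposite the ring nitrogen gives a 2.2-fold lower number from compound 2 to compound 3 (0.33 log units; beyond the scatter), the first direct measure of this change, and it shows that this position responds to a single added carbon. With that methyl held constant, 4-(hydroxycarbamoyl)butyl in place of hydroxycarbamoyl gives a 3.3-fold lower number from compound 1 to compound 3 (0.52 log units; beyond the scatter), so the side chain matters too, something the earlier pair could not show since its two compounds differ in two places at once. No measurement at hand explains the direction or size of either step.

The compounds shown leave open whether this effect belongs to methyl in particular or would also appear with an ethyl group, a chlorine atom or a methoxy group on the same carbon. They also leave open whether the methyl step would keep its size on the shorter side chain, and how a chain of intermediate length, or a carboxylic acid at the end of the chain in place of the hydroxycarbamoyl group, would read in this assay.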